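Lengthening the Thiourea Chain from Ethyl to Butyl

The compounds below may be only part of what the source reports. "The series", "measured", "known", "first", "only" and "open" are said of these compounds alone.

Compound 1 `C/C(=N\c1nc2ccc(OC(F)(F)F)cc2s1)N(C)C`: 0.1 uM
Compound 2 `CCNC(=S)Nc1nc2ccc(OC(F)(F)F)cc2s1`: 1 uM
Compound 3 `CC(C)NC(=S)Nc1nc2ccc(OC(F)(F)F)cc2s1`: 0.1 uM

All three compounds share the same core and were tested in a functional assay on Cortex (Rattus norvegicus, strain Sprague-Dawley); a lower number here means that less compound is needed, a higher number that more compound is needed for the effect. Compound 2 stands at the highest number of the three. Its nearest neighbour is compound 1, reached by a 10-fold higher number from compound 1 to compound 2 (1.00 log units; beyond the scatter); its furthest is compound 3, reached by a 10-fold lower number from compound 2 to compound 3 (1.00 log units; beyond the scatter). Compound 1 and compound 3 sit together, as no change at the digits printed from compound 1 to compound 3 (within the scatter) shows.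

Compound 4 `CCCCNC(=S)Nc1nc2ccc(OC(F)(F)F)cc2s1` is not yet measured. It differs from compound 2 in one place: ethyl in place of hydrogen on a saturated chain carbon, two bonds along the chain from an amide-type nitrogen. Among the measured compounds shown here, the step that bears most directly on this change is the one from compound 2 to compound 3, where a single methyl added to the chain carbon bound to the thiourea nitrogen gave a 10-fold lower number from compound 2 to compound 3 (1.00 log units; beyond the scatter). Compound 4 instead extends the chain outward by two carbons at the next carbon along. For the measured compounds named here, only one measured step speaks to growth of this chain, and it points toward a lower number, so a lower number is expected for compound 4 as well, though not necessarily of the full size seen for compound 3. The expected step is a 3.3-fold lower number from compound 2 to compound 4 (0.52 log units; beyond the scatter). Compound 4 is therefore estimated at 0.3 uM, with a likely range from 0.1 uM to 1 uM.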

Compound 4, minimum effective concentration: 1 uM
The estimate for compound 4 lay 3.3-fold (0.52 log units) below the measured number; measured number inside the range.
By their numbers in this assay, from the lowest: compounds 1 and 3 (each within the scatter of the next); then compounds 2 and 4 (each within the scatter of the next).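

Lengthening the chain from ethyl to butyl leaves the number where it was (no change at the digits printed from compound 2 to compound 4 (within the scatter)), so at this place the added ethyl shows no gain of the kind the single methyl gave (a 10-fold lower number from compound 2 to compound 3 (1.00 log units; beyond the scatter)). The isopropyl and butyl thioureas also stand apart (a 10-fold higher number from compound 3 to compound 4 (1.00 log units; beyond the scatter)), even though butyl is the longer group. Among the three thioureas, the lower number therefore goes with the branched isopropyl group, not with growth of the chain as such, although this rests on compound 3 alone. Nothing measured here explains this difference between branched and straight chains.

The compounds shown leave open whether the lower number holds for other branched groups on the same nitrogen, such as tert-butyl or a cyclopropyl ring. They also leave open whether propyl, which lies between ethyl and butyl, or a longer chain such as hexyl would stay level with compound 2 and compound 4 or move away from them.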